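Series notes: para-substituent on the phenyl of compound 1

The source may hold more compounds than are shown below. What is called first, only, known or untested is meant among the compounds shown, and "the series" means these compounds.

Compound 1, `C=C(C)C(=O)c1ccc(OCc2nc(-c3ccccc3)cs2)c(C)c1C`, gives 100% in an assay on HL-60 cells for inhibition of glutathione S-transferase P (Homo sapiens), read by spectrophotometry, tested at 5 uM; on this read-out higher numbers stand for more inhibition at the one concentration tested (going by the name of the read-out) and lower numbers for less inhibition. It stands level with compound 2, `C=C(C)C(=O)c1ccc(OCc2nc(-c3ccccc3)cs2)cc1C`, which gives 100%; the two are together the highest of the three numbers, and the step of no change at the digits printed from compound 1 to compound 2 (within the scatter) is flat. Compound 3, `C=C(C)C(=O)c1ccc(OCc2nc(-c3ccc([N+](=O)[O-])cc3)cs2)c(C)c1C`, gives 17.2%, so that compound 1 lies far from it: the step of a number 82.8 percentage points lower from compound 1 to compound 3 (beyond the scatter) is the only large movement seen so far.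

Compound 4, `C=C(C)C(=O)c1ccc(OCc2nc(-c3ccc(C(F)(F)F)cc3)cs2)c(C)c1C`, is not yet measured. The change from compound 1 is trifluoromethyl in place of hydrogen on an aromatic carbon. Among the compounds with values here, of the measured steps only the one from compound 1 to compound 3 bears on it, since it alters the same position of the same ring, and that step was large and downward. The step from compound 1 to compound 2 touches a different ring and gives no guidance. A single precedent with a different entering group leaves the size open; a drop is expected, but its extent is uncertain.

The estimate for compound 4 is therefore 40%, within 5% to 90%, which means an expected step of a number 60 percentage points lower from compound 1 to compound 4 (beyond the scatter).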

Compound 4, a percentage reported as inhibition, at one concentration (the size of the read-out at that concentration, not a potency): 3.6%
Compound 4: middle estimate off by 36.4 percentage points, on the high side, and the stated range ends above it.
By their numbers in this assay, from the lowest: compound 4; then compound 3; then compounds 1 and 2 (each within the scatter of the next).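

With trifluoromethyl as the second entering group on the aromatic carbon para to a large group, the step of a number 96.4 percentage points lower from compound 1 to compound 4 (beyond the scatter) in this assay shows that the loss is not confined to nitro, since both substituents tried at this place fall far short of the unsubstituted phenyl of compound 1. The two groups are not interchangeable either: the step of a number 13.6 percentage points lower from compound 3 to compound 4 (beyond the scatter) lies beyond the scatter, so the identity of the entering group still shifts the result even when inhibition is already low. No measurement is available that could explain either step, and the series therefore shows only the size of these changes and nothing of their origin.

As far as these compounds go, whether any group at this place can hold the level of compound 1 remains open, and fluorine, methoxy, an amine or a carboxylic acid on the same carbon would test how general the loss is. From the compounds shown here alone, it is also open whether trifluoromethyl or nitro has the same outcome on the core of compound 2, which carries one methyl fewer on the other aromatic ring.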